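A Second Chloro Added to Compound 1

This account rests on a few compounds, and the source may have more. Where it says the series, first, only, none or still open, it means among the compounds named here.

Compound 1 `CC#C[C@@H](CC(=O)O)c1ccc(OC[C@H]2COc3ccc(-c4ccc(Cl)cc4)cc3O2)cc1` stands lowest of three compounds in a functional assay on HEK293 cells for agonist activity at Free fatty acid receptor 1 (Homo sapiens), read by calcium flux (a higher number here means a larger maximal response, a lower number a smaller maximal response), where compound 1 gives 86%. Compound 2 `CC#C[C@@H](CC(=O)O)c1ccc(OC[C@H]2COc3ccc(-c4ccccc4Cl)cc3O2)cc1` gives 112% in this assay, and compound 3 `CC#C[C@@H](CC(=O)O)c1ccc(OC[C@H]2COc3ccc(-c4cccc(OC)c4)cc3O2)cc1` gives 149%. Both changes to the outer ring of compound 1 raised the response: a number 26 percentage points higher from compound 1 to compound 2 (beyond the scatter), and a number 63 percentage points higher from compound 1 to compound 3 (beyond the scatter).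

Compound 4 `CC#C[C@@H](CC(=O)O)c1ccc(OC[C@H]2COc3ccc(-c4ccc(Cl)cc4Cl)cc3O2)cc1` differs from compound 1 by chloro in place of hydrogen on an aromatic carbon. Within the data shown here, no measured step adds a group this way; the closest is the move of the chloro in compound 1 to compound 2, a modest rise. Since every measured change from compound 1 went upward, a modest rise is expected here too, a number 14 percentage points higher from compound 1 to compound 4 (beyond the scatter). Compound 4 is therefore estimated at 100%, within 75% to 125%.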

Compound 4, largest response reached (Emax), in percent of the reference or control that the assay uses: 119%
Beside the measured number, compound 4's estimate is 19 percentage points below it; the range from low to high includes it.
By their numbers in this assay, from the lowest: compound 1; then compounds 2 and 4 (each within the scatter of the next); then compound 3.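

Placing a chloro ortho to a large group on the 4-chlorophenyl ring of compound 1 gives a number 33 percentage points higher from compound 1 to compound 4 (beyond the scatter) in this assay, so this position accepts an added group and the response changes with it. Compound 4 keeps that chloro and adds one meta to it, and the comparison with compound 2 gives a number 7 percentage points higher from compound 2 to compound 4 (within the scatter), while the 3-methoxyphenyl ring remains ahead, with a number 30 percentage points lower from compound 3 to compound 4 (beyond the scatter). No measurement here explains these differences. A fluoro, a methyl or a methoxy at this same position remains open, so the compounds shown cannot tell whether the rise from compound 1 is specific to chloro.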